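A few compounds are considered here, and "the series" means these few. Any claim that something is new, unique, unknown or untested is made for them only; others in the source may bear on it.

Compound 3 `CC1CCN(C2CCN(S(=O)(=O)c3cccnc3F)CC2)CC1` stands at the edge of what an ADME assay on HCT-116 cells (Homo sapiens) for cytotoxicity, read by CellTiter-Glo, with a stated time of 72 h (on this read-out lower numbers stand for stronger inhibition and higher numbers for weaker inhibition), can report: compound 3 gives > 10000 nM, which is a limit of the assay and not a measured number. Compound 2 `CC1CCN(C2CCN(S(=O)(=O)c3cnc(Cl)s3)CC2)CC1` likewise gives only a limit, > 10000 nM. Compound 1 `Cc1ccc(-c2ccccc2S(=O)(=O)N2CCC(N3CCC(C)CC3)CC2)cc1` also gives a limit, > 5000 nM. Both ends of a step that the two limits leave unreadable from compound 2 to compound 3 sit at limits, so its size cannot be read. Compound 4 `CC1CCN(C2CCN(S(=O)(=O)c3ccccc3Br)CC2)CC1` differs from compound 3 by 2-bromophenyl in place of 2-fluoropyridin-3-yl on a sulfonyl sulfur. Among the compounds with values here, no measured step with a readable size bears on this change; every value shown rests at the limit of > 10000 nM in this assay, at which 2 of the 3 values shown sit, or (the limit of > 5000 nM in this assay, at which 1 of the 3 values shown sits). Compound 4 is therefore expected to stay near the limit, with a number no higher from compound 3 to compound 4 (the limit leaves the size open) meaning no change beyond the scatter. The estimate for compound 4 is 10000 nM, expected between 5000 nM and 30000 nM.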

Compound 4, half-maximal inhibitory concentration: > 5000 nM
Compound 4: a limit, no number (the forecaster's own chance of this, stated with the estimate: 85%); the middle value does not contradict the limit.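

Within the data shown here, compound 4, like compound 1, compound 2 and compound 3, gives only a limit of the assay, and no step from any of them to compound 4 can be read. From the compounds shown here alone, what number any of these four compounds would reach in this assay stays open.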